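From amino to fluoro: compound 3 to compound 4

The compounds below may be only part of what the source reports. "The series", "measured", "known", "first", "only" and "open" are said of these compounds alone.

For the measured compounds named here, in a functional assay on cells (Endothelial cell, Bos taurus) for antiproliferative activity (a lower number here means a stronger inhibitor, a higher number a weaker inhibitor), compound 3 `COc1ccc(/C(F)=C\c2cc(OC)c(OC)c(OC)c2)cc1N` gives 2100 nM, the lowest of the three numbers so far. Its hydroxy counterpart, compound 2 `COc1ccc(/C(F)=C\c2cc(OC)c(OC)c(OC)c2)cc1O`, gives 4700 nM, and compound 1 `COc1ccc(/C(F)=C/c2cc(OC)c(OC)c(OC)c2)cc1F` gives 610000 nM.

Compound 4 `COc1ccc(/C(F)=C\c2cc(OC)c(OC)c(OC)c2)cc1F` differs from compound 3 in one place: fluoro in place of amino on an aromatic carbon. This is fluoro in place of amino on an aromatic carbon, ortho to a methoxy group.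

Going by the values given here, the only measured step at this place is a 2.2-fold lower number from compound 2 to compound 3 (0.35 log units; beyond the scatter), a modest change of amino in place of hydroxy. Compound 1 also carries fluoro there, but its double bond has the opposite arrangement, so its 610000 nM is only a weak guide. Among the compounds with values here, no measured compound shows fluoro with the arrangement of compound 4. A modest to moderate rise from the lowest number is therefore a tentative expectation. The expected step in this assay is a 2.9-fold higher number from compound 3 to compound 4 (0.46 log units; beyond the scatter). For compound 4 the estimated value is 6000 nM, with an expected range of 1500 nM to 30000 nM.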

Compound 4, half-maximal inhibitory concentration: 23000 nM
The estimate for compound 4 lay 3.8-fold (0.58 log units) below the measured number; the range from low to high includes it.
By their numbers in this assay, from the lowest: compound 3; then compound 2; then compound 4; then compound 1.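

With the double bond in this arrangement, fluoro gives the highest number of the three groups at this place: in this assay the change is an 11-fold higher number from compound 3 to compound 4 (1.04 log units; beyond the scatter) and a 4.9-fold higher number from compound 2 to compound 4 (0.69 log units; beyond the scatter). The choice of group here therefore matters more than the earlier step between hydroxy and amino suggested. For the compounds shown here, compound 4 also allows the first clean reading of the double bond, with a 27-fold lower number from compound 1 to compound 4 (1.42 log units; beyond the scatter), and this large step can be put down to the arrangement alone because nothing else separates the pair: the fact that compounds 1 and 4 differ only in the configuration as drawn.

On these data alone, whether the arrangement of the double bond matters as much with amino or hydroxy at this place remains open. Also open, as far as these compounds go, is how a methyl group or a chlorine atom there would compare with these three groups.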